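A Hydroxy Group Enters on an Aromatic Carbon

The compounds below may be only part of what the source reports. "The series", "measured", "known", "first", "only" and "open" are said of these compounds alone.

Of the compounds shown here, three that share one core have been measured so far. In a functional assay on SH-SY5Y cells (Homo sapiens) for cytotoxicity, read by MTT assay, with stated times of 8 h, 30 min and 12 h, tested at 0.05 uM (on this read-out lower numbers stand for a weaker effect and higher numbers for a stronger effect at the one concentration tested), compound 1, `N=C(NCc1ccc(O)cc1)[C@@H]1CCC(=O)N1Cc1ccccc1`, gives 19.8%. Compound 2, `N=C(NCc1ccc(O)cc1)[C@@H]1CCC(=O)N1Cc1ccccc1[N+](=O)[O-]`, gives 20% in this assay, so that the step of a number 0.2 percentage points higher from compound 1 to compound 2 (within the scatter) tells of no change beyond the scatter. Compound 3, `N=C(NCc1ccccc1)[C@@H]1CCC(=O)N1Cc1ccc([N+](=O)[O-])cc1`, gives 13.7% in this assay; this is the lowest of the three numbers, yet its gaps to compound 1 and to compound 2 both lie within the scatter, so no order among the three can be claimed.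

Compound 4, `N=C(NCc1ccc(O)cc1)[C@@H]1CCC(=O)N1Cc1ccc([N+](=O)[O-])cc1`, differs from compound 3 in one place: hydroxy in place of hydrogen on an aromatic carbon. Among the measured compounds shown here, no measured step carries this same change. For the measured compounds named here, the only measured step, a number 0.2 percentage points higher from compound 1 to compound 2 (within the scatter), concerns a different group and stayed within the scatter. Compound 1 and compound 2, which both carry the hydroxy, sit within the scatter of compound 3, so the expected step is a number 3.3 percentage points higher from compound 3 to compound 4 (within the scatter), none beyond the scatter. Compound 4 is therefore estimated at 17% in this assay, within a range from 8% to 28%.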

Compound 4, a percentage reported as activity, at one concentration (the size of the read-out at that concentration, not a potency): 25.9%
Compound 4: middle estimate off by 8.9 percentage points, on the low side; the measured number falls inside the stated range.
By their numbers in this assay, from the lowest: compounds 3, 1, 2 and 4 (each within the scatter of the next, the first and the last beyond it).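

In this assay, the step of a number 12.2 percentage points higher from compound 3 to compound 4 (beyond the scatter) is the first among these compounds to go beyond the scatter, so with the 4-nitrophenyl group held in place, hydroxy in place of hydrogen on an aromatic carbon, para to a large group, raises the number by a modest amount. The two other steps into this compound, a number 5.9 percentage points higher from compound 2 to compound 4 (within the scatter) for 4-nitrophenyl in place of 2-nitrophenyl and a number 6.1 percentage points higher from compound 1 to compound 4 (within the scatter) for nitro in place of hydrogen, stay within the scatter, so neither of those changes can be said to shift the number while the hydroxy is present. Nothing given here explains the hydroxy step.

As far as these compounds go, that step rests on a single pair of compounds, so whether it holds alongside other groups on the shared core remains open. Also open, from the compounds shown here alone, is whether a methoxy group, an amine or a carboxylic acid in the place of the hydroxy would give a similar step.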